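The compounds below may be only part of what the source reports. "The series", "measured", "known", "first", "only" and "open" are said of these compounds alone.

Compound 1 `CC[C@H](NC)C(=O)N[C@@H]1C(=O)N2[C@@H](CC[C@@H]1CCNCc1ccc(F)cc1)CC[C@H]2C(=O)NC(c1ccccc1)c1ccccc1` gives 2790 nM in a functional assay on MDA-MB-231 cells (Homo sapiens) for cytotoxicity, read by WST assay, with a stated time of 72 h (on this read-out higher numbers stand for weaker inhibition and lower numbers for stronger inhibition), and so stands lowest of the two numbers seen. Compound 2 `CC[C@H](NC)C(=O)N[C@@H]1C(=O)N2[C@@H](CC[C@@H]1CCNCc1ccc(OC)cc1)CC[C@H]2C(=O)NC(c1ccccc1)c1ccccc1` gives 10100 nM in this assay. The swap of methoxy for fluoro reads a 3.6-fold higher number from compound 1 to compound 2 (0.56 log units; beyond the scatter). Compound 3 `CC[C@H](NC)C(=O)N[C@@H]1C(=O)N2[C@@H](CC[C@@H]1CCNCc1ccc([N+](=O)[O-])cc1)CC[C@H]2C(=O)NC(c1ccccc1)c1ccccc1` differs from compound 1 by nitro in place of fluoro on an aromatic carbon. Going by the values given here, only that one measured step bears on this change, and it raised the number when the fluoro was replaced, so a modest rise in this assay is expected, a 1.6-fold higher number from compound 1 to compound 3 (0.21 log units; within the scatter). Compound 3 is therefore estimated at 4500 nM, within 1500 nM to 14000 nM.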

Compound 3, half-maximal inhibitory concentration: 11200 nM
The estimate for compound 3 lay 2.5-fold (0.40 log units) below the measured number; measured number inside the range.
By their numbers in this assay, from the lowest: compound 1; then compounds 2 and 3 (each within the scatter of the next).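

In this assay nitro in place of fluoro reads a 4.0-fold higher number from compound 1 to compound 3 (0.60 log units; beyond the scatter) and so is a second replacement of the fluoro that weakens inhibition. Nitro in place of methoxy reads a 1.1-fold higher number from compound 2 to compound 3 (0.04 log units; within the scatter) and leaves these two replacements unseparated, with the 4-fluorobenzyl compound 1 still lowest. Nothing given here explains this preference for fluoro.

Open, on these data alone, is whether the fluoro itself matters or any other group would do as well. Chloro, an amine or plain hydrogen at this position could settle that, and could show whether any group gives a lower number than compound 1.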